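Swapping Fluorophenyl for Pyridinyl on a Triazole Acetamide Core

This account rests on a few compounds, and the source may have more. Where it says the series, first, only, none or still open, it means among the compounds named here.

The study tests amides built on a shared core in a functional assay on BMDM cells (Mus musculus, strain C57BL/6) for inhibition, with a stated time of 2 days; on this read-out higher numbers stand for weaker inhibition and lower numbers for stronger inhibition. Compound 1 `COc1ccc(-c2cn(CC(=O)Nc3nc4ccccc4s3)nn2)cc1` gives 1330 nM in this assay. Compound 3 `Cc1csc(NC(=O)Cn2cc(-c3cccc(N)c3)nn2)n1`, which differs both in its aryl group and in the ring attached to the amide, gives 250 nM. Compound 2 `O=C(Cn1cc(-c2ccc(F)cc2)nn1)Nc1nc2ccccc2s1` reaches only > 30000 nM, which is a limit of this assay and not a number. Compound 2 therefore stands at the weak end of the three, at the limit of > 30000 nM in this assay, at which 1 of the 3 values shown sits. Going by the values given here, the only measured step bearing on this position is an at least 22-fold higher number from compound 1 to compound 2 (1.35 log units; beyond the scatter), showing that the group on this aromatic carbon can shift the read-out strongly.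

Compound 4 `O=C(Cn1cc(-c2ccncc2)nn1)Nc1nc2ccccc2s1` carries pyridin-4-yl in place of 4-fluorophenyl on an aromatic carbon. Among the compounds with values here, no measured step addresses a pyridine here, but compound 1 shows that a group bearing a hydrogen-bond acceptor at this place gave 1330 nM. The account therefore expects compound 4 to land near 6000 nM, with a range from 1000 nM to 30000 nM. This expected move corresponds to an at least 5.0-fold lower number from compound 2 to compound 4 (0.69 log units; beyond the scatter), though a second limit reading remains possible.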

Compound 4, half-maximal inhibitory concentration: 50 nM
Beside the measured number, compound 4's estimate is 120-fold (2.08 log units) above it; measured number below the stated range.
By their numbers in this assay, from the lowest: compound 4; then compound 3; then compound 1. At a limit, above all of these: compound 2.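

Putting pyridin-4-yl in place of 4-fluorophenyl gives an at least 600-fold lower number from compound 2 to compound 4 (2.77 log units; beyond the scatter) in this assay, so this place on the shared core can reach far lower numbers than the two substituted phenyl groups had suggested. Pyridin-4-yl also gives a 27-fold lower number from compound 1 to compound 4 (1.42 log units; beyond the scatter) when it replaces 4-methoxyphenyl, which shows that the better of the two phenyl groups did not mark the low end at this position. The first of these steps has a limit of the assay, not a number, at its compound 2 end: the limit of > 30000 nM in this assay, at which 1 of the 4 values shown sits.

The compounds shown leave open whether pyridin-3-yl or pyridin-2-yl at this place would give a number like that of compound 4. They also leave open how an amine or a carboxylic acid on the pyridine ring would read, and whether pyridin-4-yl holds its effect when the ring on the amide changes.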